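Removing a methyl from the aroyl ring of a hydroxamic acid

A few compounds are considered here, and "the series" means these few. Any claim that something is new, unique, unknown or untested is made for them only; others in the source may bear on it.

Compound 1, `Cc1ccc(C(=O)N(CC(=O)NCc2ccccc2)Cc2ccc(C(=O)NO)cc2)c(C)c1`, was tested in an assay on Sf9 cells for inhibition of protein deacetylase HDAC6 (Homo sapiens), read by fluorescence, with a stated time of 90 min (a lower number here means a stronger inhibitor, a higher number a weaker inhibitor), where compound 1 gives 60 nM. Compound 2, `CNC(=O)CN(Cc1ccc(C(=O)NO)cc1)C(=O)c1ccc(C(C)C)cc1`, gives 60 nM in this assay, which sits level with compound 1 at the digits shown, and the two together stand at the lowest numbers of the three measured compounds. Compound 3, `CC(C)c1ccc(C(=O)N(Cc2ccc(C(=O)NO)cc2)C(C)(C)C(=O)NC2CCCCC2)cc1`, gives 270 nM in this assay, the highest number of the set and further from compound 1 than the usual scatter allows.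

The unmeasured compound 4, `Cc1ccccc1C(=O)N(CC(=O)NCc1ccccc1)Cc1ccc(C(=O)NO)cc1`, is derived from compound 1 by the change hydrogen in place of methyl on an aromatic carbon: a methyl, one heavy atom with no ring, no donors and no acceptors, leaves an aromatic carbon of a six-membered aromatic ring of carbon only, meta to a methyl group and para to a large group, and a hydrogen takes its place. Among the measured compounds shown here, no pair of measured compounds differs by this change alone, so the size of the step is not known from the data. A small loss in inhibition is expected, of a size near the edge of the scatter, though a step in neither direction beyond the scatter would also be unsurprising. Compound 4 is accordingly estimated to give 90 nM in this assay, within a range from 40 nM to 220 nM, which means an expected step of a 1.5-fold higher number from compound 1 to compound 4 (0.18 log units; within the scatter).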

Compound 4, half-maximal inhibitory concentration: 30 nM
Beside the measured number, compound 4's estimate is 3.0-fold (0.48 log units) above it, and the stated range ends above it.
By their numbers in this assay, from the lowest: compounds 4, 1 and 2 (each within the scatter of the next); then compound 3.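

In this assay, putting hydrogen in place of methyl on this aromatic carbon gives a 2.0-fold lower number from compound 1 to compound 4 (0.30 log units; within the scatter) and so turns 2,4-dimethylphenyl into 2-methylphenyl without a change that can be told from the scatter. The earlier compounds shown here differ from one another in more than one place and could say nothing about this methyl alone; this pair shows that, on the core of compound 1, inhibition at this level does not need it. Nothing measured here offers an explanation for this result.

The compounds shown leave open what a larger or different group on the same aromatic carbon would give, such as a methoxy group, a chlorine atom, an amine or a carboxylic acid, and whether the methyl that remains in compound 4 can also give way to hydrogen. Going by these compounds, this is also a single pair, so whether the same change would give a similar step on the aroyl ring of another compound in the set remains unknown.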